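Chloro for trifluoromethyl on the benzylic ester of the pyridinone series

The compounds below may be only part of what the source reports. "The series", "measured", "known", "first", "only" and "open" are said of these compounds alone.

Measured so far in an assay on isolated protein for inhibition of matrix metalloproteinase-9 (Homo sapiens); a higher number here means a weaker inhibitor, a lower number a stronger inhibitor:
- compound 1 `O=C(OCc1cccc(C(F)(F)F)c1)c1cccc(=O)[nH]1`: > 150 nM
- compound 2 `O=C(OCc1cccc(C(F)(F)F)c1)c1cccc(S)n1`: 126000 nM
- compound 3 `O=C(OC1CCC1)c1cccc(=O)[nH]1`: 62000 nM

Compound 1 carries only a limit, > 150 nM, and that is a limit of this assay, not a number (the limit of > 150 nM in this assay, at which 1 of the 3 values shown sits). Compound 2 gives 126000 nM. Compound 3 gives 62000 nM. Among the measured compounds shown here, the one step between measured compounds, a step that the limit leaves unreadable from compound 1 to compound 2, cannot be read because of the limit on compound 1.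

Compound 4 `O=C(OCc1cccc(Cl)c1)c1cccc(=O)[nH]1` differs from compound 1 by chloro in place of trifluoromethyl on an aromatic carbon. For the measured compounds named here, no measured step touches this part of the molecule, and the only step that exists is unreadable, so no size or direction can be drawn from the data. Compounds 2 and 3 sit far weaker than the limit of compound 1, and the limit on compound 1 itself does not say how far it lies beyond it.

The estimate for compound 4 is therefore set broadly: 40000 nM, between 2000 nM and 300000 nM, which would mean an expected step that the limit leaves unreadable from compound 1 to compound 4, with a fair chance that this assay again reports only a limit.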

Compound 4, half-maximal inhibitory concentration: 67000 nM
Compound 4: middle estimate off by 1.7-fold (0.22 log units), on the low side; measured number inside the range.
By their numbers in this assay, from the lowest: compounds 3, 4 and 2 (each within the scatter of the next, the first and the last beyond it).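

No step can be read between compound 1 and compound 4, because compound 1 carries only a limit of the assay and not a number: the limit of > 150 nM in this assay, at which 1 of the 4 values shown sits.

The compounds shown leave open what chloro in place of trifluoromethyl on an aromatic carbon does to the value, with no pair of readable numbers covering that change.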